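Working notes: acetyl to iodo on the aromatic ring

The compounds below may be only part of what the source reports. "The series", "measured", "known", "first", "only" and "open" are said of these compounds alone.

Measured so far in a functional assay on HCT-116 cells (Homo sapiens) for cytotoxicity, read by MTT assay, with a stated time of 72 h; a lower number here means a stronger inhibitor, a higher number a weaker inhibitor:
- compound 1 `Cc1ccc(S(=O)(=O)n2cc(COC3=C/C(=N\c4ccccc4)c4ccccc4C3=O)nn2)cc1` gives 5370 nM
- compound 2 `CC(=O)c1ccc(/N=C2\C=C(OCc3cn(S(=O)(=O)c4ccc(C)cc4)nn3)C(=O)c3ccccc32)cc1` gives 6270 nM

Among the compounds with values here, compound 2 stands within the scatter of compound 1, the only other measured compound, so the two cannot be ranked. The next compound to be considered is compound 3 `Cc1ccc(S(=O)(=O)n2cc(COC3=C/C(=N\c4ccc(I)cc4)c4ccccc4C3=O)nn2)cc1`, which has not yet been measured. Its difference from compound 2 is iodo in place of acetyl on an aromatic carbon and reads in words as iodo in place of acetyl on an aromatic carbon, para to a large group.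

Within the data shown here, one measured step bears on this change: a 1.2-fold higher number from compound 1 to compound 2 (0.07 log units; within the scatter), with acetyl in place of hydrogen on an aromatic carbon. Among the measured compounds shown here, no measured compound carries iodo, so this evidence is indirect. On the strength of that single small step, no change beyond the scatter is expected in this assay, and no direction is favoured. The step expected from the estimate is a 1.3-fold lower number from compound 2 to compound 3 (0.10 log units; within the scatter) for this change. For compound 3 the estimated value is 5000 nM, with an expected range from 2000 nM to 11000 nM as the measurement is awaited.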

Compound 3, half-maximal inhibitory concentration: > 16300 nM
Compound 3 was reported as a limit (the forecaster's own chance of this, stated with the estimate: 3%); middle value at least 3.2-fold (0.51 log units) from the limit.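

In this assay compound 3 is reported only as a limit, not as a number: the limit of > 16300 nM in this assay, at which 1 of the 3 values shown sits. Until now this aromatic carbon, para to a large group, had shown no readable sensitivity, since the only measured change there was a 1.2-fold higher number from compound 1 to compound 2 (0.07 log units; within the scatter); iodo now gives an at least 2.5-fold higher number from compound 2 to compound 3 (0.41 log units; beyond the scatter), and against hydrogen at the same carbon it gives an at least 3.0-fold higher number from compound 1 to compound 3 (0.48 log units; beyond the scatter). The position therefore does respond to what it carries, and the response does not follow the count of heavy atoms in these compounds, as acetyl, with 3 heavy atoms, stays within the scatter of hydrogen, while iodo, with 1, moves beyond it toward weaker inhibition.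

From the compounds shown here alone, the true size of both steps remains unknown, as each is only a lower bound set by the limit on compound 3. The compounds shown also leave open whether this weakening belongs to iodo alone or extends to chloro or bromo at the same carbon, and how an amine or a carboxylic acid would read there.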